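Dithiocarbamate chromones: morpholine in place of diisopropylamine

The source may report more compounds than this note shows. Statements on the series, on what has been measured and on what is new or still open speak of the compounds shown alone.

Working notes on the series. The shared core carries a dithiocarbamate joined through a methylene; compound 1 `CCOC(=O)c1cc(=O)c2cc(CSC(=S)N(C(C)C)C(C)C)ccc2o1` bears an ethyl ester and a diisopropylamino group. In a functional assay on SW480 cells (Homo sapiens) for antiproliferative activity, read by MTT assay, with a stated time of 72 h (on this read-out higher numbers stand for weaker inhibition and lower numbers for stronger inhibition), compound 1 gives > 25000 nM, a limit of the assay and not a number. Compound 1 therefore stands at the limit of > 25000 nM in this assay, at which 2 of the 3 values shown sit. Compound 3 `CC(C)N(C(=S)SCc1cc(=O)c2ccc(Cl)cc2o1)C(C)C`, the other diisopropylamino member, gives > 25000 nM in this assay, again a limit. Going by the values given here, compound 2 `O=c1c(CSC(=S)N2CCCC2)coc2ccccc12`, with a pyrrolidine on the thiocarbonyl carbon and no ester, gives 2300 nM in this assay, the only value that is a number; it differs from compound 1 in more than one place, so no single step can be read from it. Compound 4 `CCOC(=O)c1cc(=O)c2cc(CSC(=S)N3CCOCC3)ccc2o1` carries morpholin-4-yl in place of diisopropylamino on a thiocarbonyl carbon. Among the compounds with values here, no step between measured compounds links these two groups. The step expected an at least 1.6-fold lower number from compound 1 to compound 4 (0.22 log units; that floor lies within the scatter) is toward stronger inhibition, of modest size and possibly still within the scatter. Compound 4 is estimated at 15000 nM, with a range from 4000 nM to 40000 nM.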

Compound 4, half-maximal inhibitory concentration: > 25000 nM
Compound 4 gave a limit, no number (the forecaster's own chance of this, stated with the estimate: 45%); at least 1.6-fold (0.22 log units) between middle value and limit.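

Compound 1 and compound 4 both sit at a limit and not at a number, so no step can be read between them: the limit of > 25000 nM in this assay, at which 3 of the 4 values shown sit.

The compounds shown leave open how morpholin-4-yl and diisopropylamino on a thiocarbonyl carbon compare in this assay on the core of compound 1.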